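This account rests on a few compounds, and the source may have more. Where it says the series, first, only, none or still open, it means among the compounds named here.

Measured so far in an assay on isolated protein for inhibition of aldehyde dehydrogenase 1A1 (Homo sapiens), read by spectrophotometry, tested at 10 uM; on this read-out lower numbers stand for less inhibition and higher numbers for more inhibition at the one concentration tested (going by the name of the read-out):

- compound 1 `Cc1cccc(Cn2c(CN3CCN(C(=O)c4cccs4)CC3)nc3ccccc32)c1`: 60.8%
- compound 2 `Cc1cccc(Cn2c(CN3CCN(C(=O)c4ccc(C(F)(F)F)cc4)CC3)nc3ccccc32)c1`: 22.9%
- compound 3 `Cc1cccc(Cn2c(CN3CCN(C(=O)c4cccnc4)CC3)nc3ccccc32)c1`: 24.5%

Compound 3 stands second highest of the three numbers in this assay. Its nearest neighbour is compound 2, a number 1.6 percentage points higher from compound 2 to compound 3 (within the scatter), so the two are not separable. The furthest is compound 1, a number 36.3 percentage points lower from compound 1 to compound 3 (beyond the scatter).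

Compound 4 `Cc1cccc(Cn2c(CN3CCN(C(=O)c4ccc(C#N)cc4)CC3)nc3ccccc32)c1` differs from compound 3 in one place: 4-cyanophenyl in place of pyridin-3-yl on a carbonyl carbon.

For the measured compounds named here, two measured steps bear on this. The step of a number 1.6 percentage points higher from compound 2 to compound 3 (within the scatter) compares pyridin-3-yl with a carbon-only six-membered aromatic ring carrying trifluoromethyl, and it lies within the scatter. Going by the values given here, the steps of a number 37.9 percentage points lower from compound 1 to compound 2 (beyond the scatter) and a number 36.3 percentage points lower from compound 1 to compound 3 (beyond the scatter) are both large, but both start from thiophen-2-yl, which is not involved here; they show only that the two six-membered rings sit together well below compound 1. Going from pyridin-3-yl to 4-cyanophenyl, another carbon-only six-membered ring bearing a single acceptor group, no step beyond the scatter is therefore expected in this assay; the expected step is a number 0.5 percentage points higher from compound 3 to compound 4 (within the scatter). Compound 4 is estimated at 25%, within a range of 10% to 42%.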

Compound 4, a percentage reported as inhibition, at one concentration (the size of the read-out at that concentration, not a potency): 20.8%
The estimate for compound 4 lay 4.2 percentage points above the measured number, and the stated range covers the measured number.
By their numbers in this assay, from the lowest: compounds 4, 2 and 3 (each within the scatter of the next); then compound 1.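

In this assay the step to 4-cyanophenyl reads as a number 3.7 percentage points lower from compound 3 to compound 4 (within the scatter) and cyano in place of trifluoromethyl on an aromatic carbon reads as a number 2.1 percentage points lower from compound 2 to compound 4 (within the scatter) so pyridin-3-yl, 4-(trifluoromethyl)phenyl and 4-cyanophenyl on this carbonyl carbon cannot be told apart. The new ring also shows the drop from thiophen-2-yl, as a number 40 percentage points lower from compound 1 to compound 4 (beyond the scatter) and compound 1 therefore stands apart from compounds 2, 3 and 4. Nothing measured here accounts for that separation.

As far as these compounds go, whether the higher number belongs to thiophen-2-yl specifically or to five-membered aromatic rings more widely remains open. Furan-2-yl, thiophen-3-yl or unsubstituted phenyl on the same carbonyl carbon would bear on that question.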